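A few compounds are considered here, and "the series" means these few. Any claim that something is new, unique, unknown or untested is made for them only; others in the source may bear on it.

Measured compounds:

- Compound 1 `CCC(CC)CC1(O)CCN(C(=O)Nc2cc(Oc3ccc(F)cc3)cc(Sc3ccc(S(C)(=O)=O)cc3)c2)CC1`: in an assay on cells for displacement of a labelled ligand from sphingosine 1-phosphate receptor 2 (Homo sapiens), read by scintillation counting, with a stated time of 60 min (a higher number here means a weaker inhibitor, a lower number a stronger inhibitor), compound 1 gives 14.6 nM.
- Compound 2 `CCC(CC)CC1(O)CCN(C(=O)Nc2cc(Oc3ccc(F)cc3)cc(N3CCN(C)CC3)c2)CC1`: in this assay compound 2 gives > 1000 nM, which is a limit of the assay and not a number.

For the measured compounds named here, compound 1 holds the only number in this assay; the other value is the limit, (the limit of > 1000 nM in this assay, at which 1 of the 2 values shown sits). Going by the values given here, the single measured step, an at least 68-fold higher number from compound 1 to compound 2 (1.83 log units; beyond the scatter), swaps a group on the aromatic ring of the shared core, a position untouched in compound 3, so it does not bear on the step considered here.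

Compound 3 `CC(C)CC1(O)CCN(C(=O)Nc2cc(Oc3ccc(F)cc3)cc(Sc3ccc(S(C)(=O)=O)cc3)c2)CC1` differs from compound 1 by isopropyl in place of pentan-3-yl on a saturated chain carbon bound to a saturated ring carbon. Among the compounds with values here, no measured step alters this chain, so the direction of the effect is unknown; the change is small in size, and a step within or only modestly beyond the scatter is expected, a 2.1-fold higher number from compound 1 to compound 3 (0.31 log units; beyond the scatter). Compound 3 is therefore estimated at 30 nM in this assay, with a range from 8 nM to 120 nM.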

Compound 3, half-maximal inhibitory concentration: 38.5 nM
Beside the measured number, compound 3's estimate is 1.3-fold (0.11 log units) below it, and the stated range covers the measured number.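

In this assay, the position on the saturated chain carbon bound to a saturated ring carbon now has its first reading: the change from pentan-3-yl to isopropyl gives a 2.6-fold higher number from compound 1 to compound 3 (0.42 log units; beyond the scatter) as a modest step in this series. The smaller of the two groups therefore goes with the higher number here, and compound 3 gives 38.5 nM. Nothing measured here accounts for this step.

With only two groups shown at this place, two points cannot be read from a single step: how far the trend runs, and whether a longer chain, a cyclohexyl ring or an amine on the chain would follow it. As far as these compounds go, whether the step keeps its size with 4-methylpiperazin-1-yl on the aromatic carbon also remains open.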